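Series notes: carboxy to acetylpyrrolidinyl in compound 2

The compounds below may be only part of what the source reports. "The series", "measured", "known", "first", "only" and "open" are said of these compounds alone.

Three compounds of the shared core have been examined in a functional assay on HEK293 cells for agonist activity at nuclear receptor subfamily 1 group D member 1 (Homo sapiens), read by a luciferase reporter, with a stated time of 24 h; a higher number here means that more compound is needed for the effect, a lower number that less compound is needed. Compound 1 `CC(C)(C)OC(=O)CN(Cc1ccc(Cl)cc1)Cc1cnc[nH]1` is recorded in this assay as "not determined" (no result reported). Compound 2 `O=C(O)CN(Cc1ccc(Cl)cc1)Cc1ccc([N+](=O)[O-])s1` likewise returns "not determined" (no result reported), so compound 2 stands without a single number, and one further entry, compound 1, is in the same position. The only figure in hand comes from compound 3 `Cc1ccc(S(=O)(=O)N(Cc2ccc(Cl)cc2)Cc2ccc([N+](=O)[O-])s2)cc1`, which in this assay gives 2500 nM.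

Compound 4 `CC(=O)N1CCC(CN(Cc2ccc(Cl)cc2)Cc2ccc([N+](=O)[O-])s2)C1` is next to be measured. Relative to compound 2 the change is 1-acetylpyrrolidin-3-yl in place of carboxy on a saturated chain carbon bound to an amine nitrogen. Going by the values given here, no measured step between related compounds is available, so the size and direction of the step to compound 4 cannot be read from the numbers; the expectation is a step of modest size in either direction, near the usual scatter, with the only anchor being compound 3 at 2500 nM. Compound 4 is expected to give about 3000 nM in this assay, with a range from 800 nM to 12000 nM.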

Compound 4, half-maximal effective concentration: 1600 nM
The estimate for compound 4 lay 1.9-fold (0.27 log units) above the measured number; low and high end bracket the measured number.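

Going by these compounds alone, compound 2 has no single number in this assay and so no step from it to compound 4 can be read. The compounds shown leave open what 1-acetylpyrrolidin-3-yl in place of carboxy does on its own. No supporting evidence bears on this result.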